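The source may hold more compounds than are shown below. What is called first, only, known or untested is meant among the compounds shown, and "the series" means these compounds.

Compound 1 `Nc1cc(N)c2nc(-c3ccccc3)c(Oc3ccc(Cl)c(Cl)c3)nc2c1`, compound 2 `CCOC(=O)[C@H](CCC(=O)O)NC(=O)c1ccc(CNc2nc3cc(N)cc(N)c3nc2-c2ccccc2)cc1`, compound 3 `Nc1cc(N)c2nc(-c3ccccc3)c(NCc3ccc(Cl)c(Cl)c3)nc2c1`.

In a functional assay on UO-31 cells (Homo sapiens) for inhibition, read by sulforhodamine B assay, with a stated time of 48 h (a lower number here means a stronger inhibitor of growth, a higher number a weaker inhibitor of growth), compound 1 gives 4070 nM. In this assay compound 3 gives 4170 nM. For compound 2 the same assay returns only a limit of the assay, < 100000 nM, and not a number. Of the two numbers, compound 3 carries the higher one, but its gap to compound 1 lies within the usual scatter, so the two cannot be told apart on this evidence.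

Compound 4 `COc1ccc(CNc2nc3cc(N)cc(N)c3nc2-c2ccccc2)cc1OC` has not yet been measured. It differs from compound 3 in one place: 3,4-dimethoxyphenyl in place of 3,4-dichlorophenyl on a saturated chain carbon bound to a nitrogen on an aromatic ring. For the measured compounds named here, no measured pair shows this change directly, so its effect can only be guessed. A modest step toward a weaker inhibitor of growth is expected, a 1.9-fold higher number from compound 3 to compound 4 (0.28 log units; within the scatter), though a step within the scatter would not be surprising. Compound 4 is therefore expected to give about 8000 nM in this assay, with a likely range from 2500 nM to 25000 nM.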

Compound 4, concentration for 50% growth inhibition: 13500 nM
Compound 4: the middle estimate sits 1.7-fold (0.23 log units) below what was measured, within the range that was stated.
By their numbers in this assay, from the lowest: compounds 1 and 3 (each within the scatter of the next); then compound 4.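

On a saturated chain carbon bound to a nitrogen on an aromatic ring, the groups carried by the ring make a measurable difference: in this assay, 3,4-dimethoxyphenyl in place of 3,4-dichlorophenyl gives a 3.2-fold higher number from compound 3 to compound 4 (0.51 log units; beyond the scatter) and so a weaker inhibitor of growth. For the compounds shown here, this is the first direct comparison of two compounds that differ in one place, and it shows that this position is not indifferent to change, although the step is modest. No measurement shown here accounts for the direction of this step.

As far as these compounds go, it remains open whether the shift follows the loss of the two chlorine atoms or the arrival of the two methoxy groups. From the compounds shown here alone, how an unsubstituted phenyl, a 4-fluorophenyl or a pyridine ring would behave at this place also remains open.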